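The compounds below may be only part of what the source reports. "The series", "measured", "known", "first", "only" and "open" are said of these compounds alone.

Measured compounds:
- compound 1, `Cc1ccc2c(=O)c(CSC(=S)N3CCCC3)coc2c1` — 5900 nM
- compound 2, `Cc1ccc2c(=O)c(CSC(=S)N(C(C)C)C(C)C)coc2c1` — > 25000 nM
- compound 3, `O=c1c(CSC(=S)N2CCCC2)coc2cc(Cl)ccc12` — 7800 nM

In a functional assay on SW480 cells (Homo sapiens) for antiproliferative activity, read by MTT assay, with a stated time of 72 h (on this read-out lower numbers stand for stronger inhibition and higher numbers for weaker inhibition), compound 3 gives the highest of the two numbers shown; its nearest neighbour, compound 1, shows a 1.3-fold higher number from compound 1 to compound 3 (0.12 log units; within the scatter). For compound 2 the assay reports only a limit, (the limit of > 25000 nM in this assay, at which 1 of the 3 values shown sits).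

Compound 4, `CC(C)N(C(=S)SCc1coc2cc(Cl)ccc2c1=O)C(C)C`, is not yet measured. It differs from compound 3 by diisopropylamino in place of pyrrolidin-1-yl on a thiocarbonyl carbon. The same change has been measured once, between compound 1 and compound 2, where it gave an at least 4.2-fold higher number from compound 1 to compound 2 (0.62 log units; beyond the scatter). Among the compounds with values here, that measured step bears directly on the one from compound 3 to compound 4, since both start from a pyrrolidin-1-yl on the thiocarbonyl carbon and end at diisopropylamino, with the rest of the shared core unchanged.

The number for compound 4 in this assay is therefore expected to rise by a step of about a 4.5-fold higher number from compound 3 to compound 4 (0.65 log units; beyond the scatter), well beyond the scatter, and quite possibly to reach only a limit. Compound 4 is estimated at 35000 nM, with a range from 15000 nM to 100000 nM.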

Compound 4, half-maximal inhibitory concentration: > 25000 nM
Compound 4 gave a limit, no number; the forecaster's own chance of this, stated with the estimate: 75%; the middle value is on the limit's open side.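

In this assay, the change from pyrrolidin-1-yl to diisopropylamino on a thiocarbonyl carbon now has a second reading, with chloro in place of methyl on the aromatic carbon, and it points the same way: an at least 3.2-fold higher number from compound 3 to compound 4 (0.50 log units; beyond the scatter). The direction of the change therefore holds on both cores shown, while its size on each remains uncertain: the same change on two cores in this assay, an at least 4.2-fold higher number (0.62 log units; beyond the scatter) from compound 1 to compound 2 and an at least 3.2-fold higher number (0.50 log units; beyond the scatter) from compound 3 to compound 4; the limit leaves it open whether they differ Compound 2 and compound 4 both stand at a limit, so the step between them cannot be read, and chloro against methyl can be compared only with pyrrolidin-1-yl in place: the limit of > 25000 nM in this assay, at which 2 of the 4 values shown sit.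

The compounds shown leave open how far the diisopropylamino compounds lie past that limit. They also leave open how a diethylamino or a morpholin-4-yl on the thiocarbonyl carbon would read in this assay.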